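Aryl swaps on the hydrazone series: towards compound 4

The source may report more compounds than this note shows. Statements on the series, on what has been measured and on what is new or still open speak of the compounds shown alone.

For the measured compounds named here, compound 3 `O=C(CSc1nnc(-c2ccncc2)o1)N/N=C/c1cc(Br)cc(Br)c1O` gives 190000 nM in an ADME assay on NIH3T3 cells (Mus musculus) for cytotoxicity, read by MTT assay, with a stated time of 24 h (on this read-out higher numbers stand for weaker inhibition and lower numbers for stronger inhibition), the highest of the three numbers so far, although compound 2 `COc1cccc(/C=N/NC(=O)CSc2nnc(-c3ccncc3)o2)c1` at 179000 nM and compound 1 `O=C(CSc1nnc(-c2ccncc2)o1)N/N=C/c1ccc(Br)cc1` at 169000 nM both sit within the scatter of it. Compound 4 `COc1cc(/C=N/NC(=O)CSc2nnc(-c3ccncc3)o2)ccc1O` is compound 3 with 4-hydroxy-3-methoxyphenyl in place of 3,5-dibromo-2-hydroxyphenyl on a carbon with a double bond to nitrogen. The comparable aryl swaps on the carbon with a double bond to nitrogen were all flat: a 1.1-fold higher number from compound 1 to compound 2 (0.02 log units; within the scatter), a 1.1-fold higher number from compound 1 to compound 3 (0.05 log units; within the scatter) and a 1.1-fold higher number from compound 2 to compound 3 (0.03 log units; within the scatter). Three different aryl groups at that position gave no step beyond the scatter, so none is expected in this assay here either. The expected step is a 1.0-fold lower number from compound 3 to compound 4 (0.01 log units; within the scatter). Compound 4 is therefore estimated at 185000 nM, with a range of 100000 nM to 350000 nM.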

Compound 4, half-maximal inhibitory concentration: 148000 nM
Estimate against measurement, compound 4: 1.3-fold (0.10 log units) above, within the range that was stated.
By their numbers in this assay, from the lowest: compounds 4, 1, 2 and 3 (each within the scatter of the next).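

In this assay a fourth aryl group on the carbon with a double bond to nitrogen stays flat, with a 1.3-fold lower number from compound 3 to compound 4 (0.11 log units; within the scatter) and a 1.1-fold lower number from compound 1 to compound 4 (0.06 log units; within the scatter) as its steps. Hydroxy in place of hydrogen on an aromatic carbon, a smaller change on the aryl group, gives a 1.2-fold lower number from compound 2 to compound 4 (0.08 log units; within the scatter) and so also stays within the scatter. No evidence is available to explain this flatness.

Still open, from the compounds shown here alone, is whether an amine or a carboxylic acid on this aryl group, or an alkyl chain in its place, would move the number beyond the scatter.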